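Adding a second fluorine to the phenyl ring of compound 2

This account rests on a few compounds, and the source may have more. Where it says the series, first, only, none or still open, it means among the compounds named here.

Of the compounds shown here, two sharing one core have been measured in a functional assay on A549 cells (Homo sapiens) for inhibition, read by MTT assay, with a stated time of 72 h; a higher number here means a weaker inhibitor, a lower number a stronger inhibitor. Compound 1, `COc1cc2c(Oc3ccc(NC(=O)c4nn(-c5ccccc5)c(=O)cc4C)cc3F)ccnc2cc1OCCCN1CCCC1`, gives 370 nM. Compound 2, `COc1cc2c(Oc3ccc(NC(=O)c4nn(-c5cccc(F)c5)c(=O)cc4C)cc3F)ccnc2cc1OCCCN1CCCC1`, gives 170 nM. Among the measured compounds shown here, on these two numbers compound 2 stands lowest, and its only neighbour is compound 1; the step of a 2.2-fold lower number from compound 1 to compound 2 (0.34 log units; beyond the scatter) describes that difference.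

The unmeasured compound 3, `COc1cc2c(Oc3ccc(NC(=O)c4nn(-c5ccc(F)c(F)c5)c(=O)cc4C)cc3F)ccnc2cc1OCCCN1CCCC1`, differs from compound 2 by a single change: fluoro in place of hydrogen on an aromatic carbon. The same kind of change, a fluoro in place of hydrogen on an aromatic carbon, was seen once before, in the step from compound 1 to compound 2, and it gave a modest but real lowering of the number. One earlier step is a thin basis, and the new fluoro enters at a different carbon of the same ring, ortho to the fluoro already present. A further small lowering, or no step beyond the scatter, is the expectation in this assay; the expected step is a 1.3-fold lower number from compound 2 to compound 3 (0.12 log units; within the scatter). Compound 3 is therefore estimated at 130 nM, within a range from 55 nM to 330 nM.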

Compound 3, half-maximal inhibitory concentration: 220 nM
For compound 3 the middle estimate is 1.7-fold (0.23 log units) below the measured one; low and high end bracket the measured number.
By their numbers in this assay, from the lowest: compounds 2, 3 and 1 (each within the scatter of the next, the first and the last beyond it).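

In this assay, among the compounds shown here, the second fluoro, placed ortho to the first and para to a large group, brings a 1.3-fold higher number from compound 2 to compound 3 (0.11 log units; within the scatter) and so gives no step that can be told apart from the usual scatter. For the compounds shown here, the first fluoro on this ring had given a 2.2-fold lower number from compound 1 to compound 2 (0.34 log units; beyond the scatter), so the earlier compounds alone could not show that the same replacement of hydrogen by fluoro can fall within the scatter at another carbon of the ring. Measured against the plain phenyl group of compound 1, the 3,4-difluorophenyl group gives a 1.7-fold lower number from compound 1 to compound 3 (0.23 log units; within the scatter), which also lies within the scatter, and no measurement at hand accounts for either step.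

What the compounds shown leave open is whether a chlorine atom, a methoxy group or an amine at this same carbon would move the number beyond the scatter. They also leave open what a fluoro at this carbon would do on a ring that carries no other fluoro, since here it appears only alongside the first one.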